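Swapping chloro for fluoro on a bithiophene amidine

This account rests on a few compounds, and the source may have more. Where it says the series, first, only, none or still open, it means among the compounds named here.

Two amidines built on a shared core have been measured so far. Compound 1 `N=C(N)c1ccc(-c2ccc(-c3ccc(Cl)cc3)s2)s1` gives 2110 nM in a functional assay on BT-549 cells (Homo sapiens) for inhibition, read by sulforhodamine B assay, with a stated time of 48 h (on this read-out higher numbers stand for weaker inhibition of growth and lower numbers for stronger inhibition of growth), and compound 2 `N=C(N)c1ccc(-c2ccc(-c3ccc(F)cc3)o2)o1` gives 2270 nM in this assay. Compound 1 has the lowest of the two numbers, but its nearest neighbour, compound 2, lies within the scatter of it, so the two values show no difference that can be read as order.

The account now follows compound 1 to compound 3 `N=C(N)c1ccc(-c2ccc(-c3ccc(F)cc3)s2)s1`, which has not yet been measured in this assay. The change is fluoro in place of chloro on an aromatic carbon. For the measured compounds named here, no step between measured compounds isolates this exchange, so its size is open. The expectation is that the step from compound 1 to compound 3 in this assay amounts to a 1.2-fold higher number from compound 1 to compound 3 (0.09 log units; within the scatter), that is, none beyond the scatter or at most a small weakening. Compound 3 is therefore estimated at 2600 nM, with a range from 1200 nM to 5500 nM.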

Compound 3, concentration for 50% growth inhibition: 1890 nM
Compound 3: middle estimate off by 1.4-fold (0.14 log units), on the high side; measured number inside the range.
By their numbers in this assay, from the lowest: compounds 3, 1 and 2 (each within the scatter of the next).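

Fluoro in place of chloro on an aromatic carbon, para to a large group, now has a step of its own: in this assay the exchange gives a 1.1-fold lower number from compound 1 to compound 3 (0.05 log units; within the scatter) and stays within the scatter. Neither earlier compound could show this, as compound 1 and compound 2 differ in more than one place. At this position, then, the two halogens cannot be told apart in this read-out, and nothing shown here speaks to why that is so.

As far as these compounds go, whether a group other than a halogen at this position, such as a methoxy group or an amine, would move the number beyond the scatter stays open. Also open, from the compounds shown here alone, is whether a carboxylic acid in place of the amidine would leave growth inhibition on the shared core where it stands.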